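The compounds below may be only part of what the source reports. "The series", "measured", "known", "first", "only" and "open" are said of these compounds alone.

Of the compounds shown here, three have been read in a physicochemical assay for solubility, read by HPLC, in phosphate buffer, measured as kinetic solubility, at pH 7.4; on this read-out lower numbers stand for lower solubility and higher numbers for higher solubility. Compound 1 (`CCOC(=O)c1cc(-c2ccc(Cl)cc2)n(-c2ccc3cc[nH]c3c2)c1C`) gives 5100 nM, compound 2 (`CCC(=O)c1cc(C)n(-c2ccc(S(N)(=O)=O)cc2)c1-c1ccc(Cl)cc1`) gives 6900 nM, and compound 3 (`CCC(=O)c1cc(-c2ccc(S(N)(=O)=O)cc2)n(-c2ccc(Cl)cc2)n1`) gives 41900 nM. Compound 3 therefore stands highest of the three, and its gaps to the other two lie beyond the usual scatter of repeated measurements. No two of these compounds differ in one place only, so the data contain no measured step to serve as a direct guide.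

The next compound to be read is compound 4 (`NS(=O)(=O)c1ccc(-c2cc(C(=O)C3CCCC3)nn2-c2ccc(Cl)cc2)cc1`), which departs from compound 3 in a single place: cyclopentyl in place of ethyl on a carbonyl carbon. In words, this is cyclopentyl in place of ethyl on a carbonyl carbon. Any forecast for this change is a judgement rather than a reading. Compound 3, at 41900 nM, sits at the top of the small range seen so far, while compound 2, at 6900 nM, marks the nearest value beneath it. A fall therefore seems more likely than a rise. The expected step is a 3.5-fold lower number from compound 3 to compound 4 (0.54 log units; beyond the scatter), downward and beyond the scatter. In this assay, the estimate for compound 4 is 12000 nM, with an expected range from 4000 nM to 30000 nM.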

Compound 4, solubility: 4600 nM
Compound 4: the middle estimate sits 2.6-fold (0.42 log units) above what was measured; the range from low to high includes it.
By their numbers in this assay, from the lowest: compounds 4, 1 and 2 (each within the scatter of the next); then compound 3.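

At the carbonyl carbon, the group carried proves to matter in this assay: cyclopentyl in place of ethyl gives a 9.1-fold lower number from compound 3 to compound 4 (0.96 log units; beyond the scatter), the first measured change in one place among these compounds, and it lies beyond the scatter. The change is one of carbon only, with ethyl of 2 heavy atoms giving way to cyclopentyl of 5 and a five-membered non-aromatic ring entering, while neither group carries a hydrogen-bond donor, a hydrogen-bond acceptor or a net charge. Nothing measured here accounts for the size of this step.

The compounds shown leave open whether the step goes with the ring itself or with the larger count of carbon, as this single pair changes both at once. They also leave open how this position would read with a longer open chain such as butyl, with a smaller ring such as cyclopropyl, or with an amine on the carbonyl carbon, and whether the same change would give a step of similar size on another core.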